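The source may report more compounds than this note shows. Statements on the series, on what has been measured and on what is new or still open speak of the compounds shown alone.

Measured in a functional assay on A-431 cells (Homo sapiens) for cytotoxicity, read by MTT assay; on this read-out higher numbers stand for weaker inhibition and lower numbers for stronger inhibition:

- compound 1 `N#Cc1c(Nc2ccccc2)c(Cl)c2nc(N)nc(N)c2c1F`: 4.8 ug/mL
- compound 2 `CC(C)(C)Nc1c(C#N)c(F)c2c(N)nc(N)nc2c1Cl`: 6.5 ug/mL

Only these two compounds have been measured so far, and they stand level within the usual scatter of this assay, with compound 2 at 6.5 ug/mL. The next compound to be tested is compound 3 `CCN(CC)c1c(C#N)c(F)c2c(N)nc(N)nc2c1Cl`. Its structural change from compound 2 is diethylamino in place of (tert-butyl)amino on an aromatic carbon. The core and its chloro, cyano and fluoro groups stay as they are, and only the group on that aromatic carbon is rearranged.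

Among the measured compounds shown here, one measured step bears on this change: a 1.4-fold higher number from compound 1 to compound 2 (0.13 log units; within the scatter). That swap of phenyl for tert-butyl on the same nitrogen moved the number by no more than the scatter, which offers a modest hint that this position tolerates change. For the measured compounds named here, still, no measured compound carries diethylamino, so two compounds give only weak guidance and the range must stay wide. No clear direction can be expected. The expected change is a 1.1-fold lower number from compound 2 to compound 3 (0.03 log units; within the scatter), which would not be a real shift beyond the scatter. For compound 3 the estimated value is 6 ug/mL, with an expected range from 2.5 ug/mL to 14 ug/mL.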

Compound 3, half-maximal inhibitory concentration: 7.3 ug/mL
The estimate for compound 3 lay 1.2-fold (0.09 log units) below the measured number, within the range that was stated.
By their numbers in this assay, from the lowest: compounds 1, 2 and 3 (each within the scatter of the next).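

In this assay, the step of a 1.1-fold higher number from compound 2 to compound 3 (0.05 log units; within the scatter) exchanges (tert-butyl)amino, with 1 hydrogen-bond donor, for diethylamino, with 0 hydrogen-bond donors, while the group keeps its 5 heavy atoms, so this is a rearrangement of the same atoms and the loss of that donor together. Compound 1 and compound 2 had shown only that anilino and (tert-butyl)amino read alike, and the step of a 1.5-fold higher number from compound 1 to compound 3 (0.18 log units; within the scatter) adds that a group with no hydrogen-bond donor also stays level with anilino, so all three compounds lie within the scatter of one another in this assay. No measurement shown here offers a reason for this flat picture.

From the compounds shown here alone, all three groups are joined to the aromatic carbon through a nitrogen and carry carbon substituents, so it remains open whether a plain amino group, a ring such as morpholine, a longer chain such as dibutylamino, or a carboxylic acid would move the number beyond the scatter. Going by these compounds, whether the chloro, cyano and fluoro groups matter for this cytotoxicity also stays open, as all three compounds carry them unchanged.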